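Chain Lengthening toward Compound 4 in the Transporter Assay

This account rests on a few compounds, and the source may have more. Where it says the series, first, only, none or still open, it means among the compounds named here.

Measured compounds:
compound 1 `CNCCCCN1Cc2ccccc2N(c2ccccc2F)S1(=O)=O`: 18%
compound 2 `CNCCN1Cc2cc(F)ccc2N(c2ccccc2F)S1(=O)=O`: -5%
compound 3 `CNCCCN1Cc2cc(F)ccc2N(c2ccccc2F)S1(=O)=O`: 2.5%

In an assay on CHO cells for displacement of a labelled ligand from sodium-dependent dopamine transporter (Homo sapiens), tested at 1 uM (on this read-out lower numbers stand for less inhibition and higher numbers for more inhibition at the one concentration tested (going by the name of the read-out)), compound 3 gives 2.5%, the second highest of the three numbers; its nearest neighbour is compound 2 at -5%, within the scatter, and the furthest is compound 1 at 18%, beyond it. Compound 4 `CNCCCCN1Cc2cc(F)ccc2N(c2ccccc2F)S1(=O)=O` has not been measured. It differs from compound 3 as (methylamino)methyl in place of methylamino on a saturated chain carbon, three bonds along the chain from a sulfonamide nitrogen in a ring. Among the compounds with values here, one measured step bears on this change: a number 7.5 percentage points higher from compound 2 to compound 3 (within the scatter), the same lengthening by one chain carbon taken one bond closer to the sulfonamide nitrogen, and it stayed within the scatter. Within the data shown here, compound 1 carries the same chain as compound 4 but lacks the ring fluorine, and its value sits somewhat higher than that of compound 3; no step between compound 1 and compound 4 is available, so this remains an observation only. The account therefore expects a small upward step, a number 7.5 percentage points higher from compound 3 to compound 4 (within the scatter), possibly within the scatter. Compound 4 is estimated at 10% in this assay, with a range from -5% to 25%.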

Compound 4, a percentage reported as inhibition, at one concentration (the size of the read-out at that concentration, not a potency): 25%
The estimate for compound 4 lay 15 percentage points below the measured number; low and high end bracket the measured number.
By their numbers in this assay, from the lowest: compounds 2 and 3 (each within the scatter of the next); then compounds 1 and 4 (each within the scatter of the next).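

In this assay the lengthening at this position, three bonds along the chain from the sulfonamide nitrogen, gives a step beyond the scatter, a number a number 22.5 percentage points higher from compound 3 to compound 4 (beyond the scatter) and not the step within the scatter seen one bond closer, a number 7.5 percentage points higher from compound 2 to compound 3 (within the scatter) in the same series. Taken together, the change from methylamino to 2-(methylamino)ethyl gives a number 30 percentage points higher from compound 2 to compound 4 (beyond the scatter) and so the fluorinated series now shows a separation by chain length, while the ring fluoro makes no readable difference at this chain length, with a number 7 percentage points higher from compound 1 to compound 4 (within the scatter) as its step. The compounds shown offer no measured basis for explaining this rise.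

They leave open whether a longer chain than 4-(methylamino)butyl would extend or reverse the rise. They also leave open how a primary amine or a dimethylamino group at the chain end would read at this length.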